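The compounds below may be only part of what the source reports. "The series", "measured", "known", "first", "only" and "open" are said of these compounds alone.

In a functional assay on HeLa cells (Homo sapiens) for cytotoxicity, read by MTT assay (on this read-out lower numbers stand for stronger inhibition and higher numbers for weaker inhibition), compound 1 `COCOc1cc(C#Cc2cc(OC)c(OC)c(OC)c2)ccc1OC` gives 26800 nM, compound 3 `COCOc1cc(C2CC2c2cc(OC)c(OC)c(OC)c2)ccc1OC` gives 24000 nM, and compound 2 `COc1ccc(C#Cc2cc(OC)c(OC)c(OC)c2)cc1O` gives 1540 nM, the lowest number of the three. Compound 4 `COc1ccc(C#Cc2cc(OC)c(OC)c(OC)c2)cc1NC(=O)OC(C)(C)C` has not yet been measured. It departs from compound 2 with (tert-butoxycarbonyl)amino in place of hydroxy on an aromatic carbon. Going by the values given here, only one measured step bears on this change, and it does so indirectly: a 17-fold lower number from compound 1 to compound 2 (1.24 log units; beyond the scatter), with hydrogen in place of methoxymethyl on an oxygen on an aromatic ring. Among the compounds with values here, no measured compound carries the entering group, so a large step to a higher number in this assay is expected only tentatively. The expected change is a 7.8-fold higher number from compound 2 to compound 4 (0.89 log units; beyond the scatter). Compound 4 is estimated at 12000 nM, with an expected range from 3000 nM to 40000 nM.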

Compound 4, half-maximal inhibitory concentration: > 30000 nM
Compound 4: only a limit was reported; the forecaster's own chance of this, stated with the estimate: 15%; middle value at least 2.5-fold (0.39 log units) from the limit.
By their numbers in this assay, from the lowest: compound 2; then compounds 3 and 1 (each within the scatter of the next). At a limit, above all of these: compound 4.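

In this assay compound 4 gives > 30000 nM, which is a limit and not a number. This shows that (tert-butoxycarbonyl)amino does not take over the role of hydroxy on this aromatic carbon, with an at least 19-fold higher number from compound 2 to compound 4 (1.28 log units; beyond the scatter), so among the compounds shown, the low number still belongs to hydroxy alone. Against methoxymethoxy, the step of an at least 1.1-fold higher number from compound 1 to compound 4 (0.04 log units; that floor lies within the scatter) sets no order between the two groups. On these data alone, what stays open is whether a free amine or an acetamide on this carbon would hold the number of compound 2, and whether the loss follows from the nitrogen or from the tert-butoxycarbonyl group.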